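Varying the aryl amide group on a shared core

The compounds below may be only part of what the source reports. "The series", "measured", "known", "first", "only" and "open" are said of these compounds alone.

Three compounds share one core and differ only in the aryl group on the amide nitrogen. In an assay on isolated protein for inhibition of histone deacetylase 4 (Homo sapiens), with a stated time of 1 h (on this read-out higher numbers stand for weaker inhibition and lower numbers for stronger inhibition), compound 1 `O=C(COc1ccc2cc(/C=C3/SC(=O)NC3=O)ccc2c1)Nc1ccccc1` gives 2100 nM, compound 2 `O=C(COc1ccc2cc(/C=C3/SC(=O)NC3=O)ccc2c1)Nc1cccc(C(F)(F)F)c1` gives 2500 nM, and compound 3 `O=C(COc1ccc2cc(/C=C3/SC(=O)NC3=O)ccc2c1)Nc1ccc(F)cc1` gives 1600 nM. Compound 3 carries the lowest of the three numbers, yet its steps to the others, a 1.3-fold lower number from compound 1 to compound 3 (0.12 log units; within the scatter) and a 1.6-fold lower number from compound 2 to compound 3 (0.19 log units; within the scatter), lie within the scatter, as does a 1.2-fold higher number from compound 1 to compound 2 (0.08 log units; within the scatter). Compound 4 `Cc1ccc(NC(=O)COc2ccc3cc(/C=C4/SC(=O)NC4=O)ccc3c2)cc1Cl` carries 3-chloro-4-methylphenyl in place of 4-fluorophenyl on an amide-type nitrogen. All three measured steps concern this same aryl group and none moved beyond the scatter, so in this assay no step beyond the scatter is expected here either. Compound 4 is therefore estimated at 1900 nM, between 900 nM and 4000 nM, which means an expected step of a 1.2-fold higher number from compound 3 to compound 4 (0.07 log units; within the scatter).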

Compound 4, half-maximal inhibitory concentration: 1100 nM
The estimate for compound 4 lay 1.7-fold (0.24 log units) above the measured number; measured number inside the range.
By their numbers in this assay, from the lowest: compounds 4, 3, 1 and 2 (each within the scatter of the next, the first and the last beyond it).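

In this assay the aryl group on the amide-type nitrogen now gives its first step beyond the scatter, a 2.3-fold lower number from compound 2 to compound 4 (0.36 log units; beyond the scatter), though that step is modest. The 3-chloro-4-methylphenyl group stays within the scatter of the other two groups, with a 1.5-fold lower number from compound 3 to compound 4 (0.16 log units; within the scatter) and a 1.9-fold lower number from compound 1 to compound 4 (0.28 log units; within the scatter), so only compound 2 stands apart from compound 4. No measurement shown here bears on what lies behind this step.

The compounds shown leave open whether chloro or methyl alone would give the same number. They also leave open whether an amine or a carboxylic acid on this aryl group would move it further.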